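The source may report more compounds than this note shows. Statements on the series, on what has been measured and on what is new or still open speak of the compounds shown alone.

This account concerns four hydrazones built on a shared core. Compound 1 `O=C(N/N=C/c1ccccc1O)c1cnccn1` carries a hydroxy group, and compound 2 `O=C(N/N=C/c1ccc(O)cc1)c1cnccn1` has the same atoms joined differently; the difference between the two cores is not broken down here. Compound 3 `N#Cc1ccccc1/C=N/NC(=O)c1cnccn1` is related to compound 1, and compound 4 `N#Cc1ccc(/C=N/NC(=O)c2cnccn2)cc1` is related to compound 2 but has not yet been measured.

In an ADME assay on J774 cells (Mus musculus) for cytotoxicity, read by MTT assay, with a stated time of 48 h, tested at 50 ug/mL (on this read-out lower numbers stand for a stronger effect and higher numbers for a weaker effect at the one concentration tested), compound 1 gives 1%. In this assay compound 3 gives 92%. The change from compound 1 to compound 3 is cyano in place of hydroxy on an aromatic carbon, and it produced a step of a number 91 percentage points higher from compound 1 to compound 3 (beyond the scatter). In this assay compound 2 gives 100%, within the scatter of compound 3 and far from compound 1.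

The change from compound 2 to compound 4 is cyano in place of hydroxy on an aromatic carbon. Its place line differs from the earlier one: there the cyano stands ortho to a large group, here para to a large group, so it is the same kind of change rather than the same change. The earlier step went strongly upward, but compound 2 already sits at the top of the read-out, so no upward room remains. The step from compound 2 to compound 4 is therefore expected to be small, about a number 3 percentage points lower from compound 2 to compound 4 (within the scatter), because compound 2 gives 100% and the read-out cannot exceed it. Compound 4 is estimated at 97%, expected to lie between 85% and 100%.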

Compound 4, a percentage reported as activity, at one concentration (the size of the read-out at that concentration, not a potency): 100%
Compound 4: the middle estimate sits 3 percentage points below what was measured, within the range that was stated.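

The replacement of hydroxy by cyano on the core of compound 2 gave, in this assay, no change at the digits printed from compound 2 to compound 4 (within the scatter), with the cyano para to a large group. The same kind of change thus did not carry its size from one core to the other, and a large step on the core of compound 1 gave no guide to the size of the step on the core of compound 2: the same change on two cores in this assay, a number 91 percentage points higher (beyond the scatter) from compound 1 to compound 3 and no change at the digits printed (within the scatter) from compound 2 to compound 4, 91 percentage points apart, beyond the scatter of two such steps. This does not show why the two steps part, since the two pairs differ in where the group sits as well as in their starting values, with compound 1 at 1% and compound 2 at 100%, and a single pair on each core cannot separate these factors or say whether the contrast would hold in another read-out.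

The compounds shown carry only hydroxy and cyano on the aromatic ring, so it stays open how an amine, a carboxylic acid or a methoxy group would read at either place on these cores. Also open, going by these compounds, is whether any group other than hydroxy, in the place it holds in compound 1, would give a number as low as that compound's.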